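This account rests on a few compounds, and the source may have more. Where it says the series, first, only, none or still open, it means among the compounds named here.

Three amides on one shared core have been measured in an assay on LtK cells with ATP-sensitive inward rectifier potassium channel 11 (Homo sapiens) as the target; a higher number here means that more compound is needed for the effect, a lower number that less compound is needed. Compound 1 `CCC(C)C(=O)Nc1c(C(O)(C(F)(F)F)C(F)(F)F)ccc2ccccc12` gives 177000 nM; compound 2 `O=C(Nc1c(C(O)(C(F)(F)F)C(F)(F)F)ccc2ccccc12)C1CC1` gives 751 nM; compound 3 `O=C(Nc1c(C(O)(C(F)(F)F)C(F)(F)F)ccc2ccccc12)C1CCC1` gives 45 nM. Compound 3 holds the lowest number of the three, with a 17-fold lower number from compound 2 to compound 3 (1.22 log units; beyond the scatter) and a 3900-fold lower number from compound 1 to compound 3 (3.59 log units; beyond the scatter) both beyond the scatter; the remaining step is a 240-fold lower number from compound 1 to compound 2 (2.37 log units; beyond the scatter). Compound 4 `O=C(Nc1c(C(O)(C(F)(F)F)C(F)(F)F)ccc2ccccc12)c1cccc(Br)c1` differs from compound 3 by 3-bromophenyl in place of cyclobutyl on a carbonyl carbon. Among the compounds with values here, no measured step swaps a ring on the carbonyl carbon for an aromatic one, so the three steps bear on this change only in showing that the group on the carbonyl carbon moves the number strongly in both directions. For compound 4 the expected step is a 2.7-fold higher number from compound 3 to compound 4 (0.43 log units; beyond the scatter), a modest rise with wide uncertainty. Compound 4 is estimated at 120 nM, with a range of 12 nM to 1200 nM.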

Compound 4, half-maximal effective concentration: 80 nM
Compound 4: middle estimate off by 1.5-fold (0.18 log units), on the high side; low and high end bracket the measured number.
By their numbers in this assay, from the lowest: compounds 3 and 4 (each within the scatter of the next); then compound 2; then compound 1.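

The carbonyl carbon accepts an aromatic ring as well as a four-membered non-aromatic one: exchanging cyclobutyl for 3-bromophenyl gives a 1.8-fold higher number from compound 3 to compound 4 (0.25 log units; within the scatter), so the two groups cannot be told apart here. The advantage over the other groups remains, with a 9.4-fold lower number from compound 2 to compound 4 (0.97 log units; beyond the scatter) and a 2200-fold lower number from compound 1 to compound 4 (3.34 log units; beyond the scatter), so a low number at this position does not require a non-aromatic ring. No supporting measurement offers an explanation for these steps.

Open, on these data alone, is whether bromine adds anything beyond the phenyl ring; plain phenyl, or phenyl carrying an amine or carboxylic acid instead, would separate the two. Cyclopentyl would test whether the change from cyclopropyl to cyclobutyl extends to a larger ring.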